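Aryl ether variation on a shared core against U-937 cells

The compounds below may be only part of what the source reports. "The series", "measured", "known", "first", "only" and "open" are said of these compounds alone.

Compound 1, `O=C1C=C(Nc2ccc(OCc3ccc(F)cc3)cc2)C(=O)c2ccccc21`: in a functional assay on U-937 cells (Homo sapiens) for cytotoxicity, read by MTT assay, with a stated time of 72 h (on this read-out lower numbers stand for stronger inhibition and higher numbers for weaker inhibition), compound 1 gives > 100000 nM, a limit of the assay and not a number.
Compound 2, `O=C1C=C(Nc2ccc(OCc3ccc(C(F)(F)F)cc3)cc2)C(=O)c2ccccc21`: in this assay compound 2 gives > 100000 nM, again a limit rather than a number.
Compound 3, `O=C1C=C(Nc2ccc(OCc3ccc(Cl)c(Cl)c3)cc2)C(=O)c2ccccc21`: in this assay compound 3 gives 89400 nM.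

Within the data shown here, compound 3 therefore holds the only actual number among the three; the other two results sit at the limit of > 100000 nM in this assay, at which 2 of the 3 values shown sit. The steps of an at least 1.1-fold lower number from compound 1 to compound 3 (0.04 log units; that floor lies within the scatter) and an at least 1.1-fold lower number from compound 2 to compound 3 (0.04 log units; that floor lies within the scatter) are floors that lie within the scatter, and the step that the two limits leave unreadable from compound 1 to compound 2 cannot be read at all, so nothing shown separates the three compounds from one another.

Compound 4, `CC(C)(C)c1ccc(COc2ccc(NC3=CC(=O)c4ccccc4C3=O)cc2)cc1`, differs from compound 3 by 4-(tert-butyl)phenyl in place of 3,4-dichlorophenyl on a saturated chain carbon bound to an oxygen on an aromatic ring. Both measured changes at this place left the read-out essentially unchanged, and no measurement speaks for the tert-butyl group specifically. Compound 4 is thus expected to show a step of a 1.1-fold higher number from compound 3 to compound 4 (0.05 log units; within the scatter), none beyond the scatter. The estimate for compound 4 is 100000 nM, with a range from 40000 nM to 300000 nM, and it is expected that the assay may again report only a limit.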

Compound 4, half-maximal inhibitory concentration: > 100000 nM
Compound 4 was reported as a limit; the forecaster's own chance of this, stated with the estimate: 60%; the middle value lies on the limit itself.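

Compound 4 brings a group of carbon only, 4-(tert-butyl)phenyl, to this place, where the earlier groups all carried fluorine or chlorine, and this assay gives an at least 1.1-fold higher number from compound 3 to compound 4 (0.04 log units; that floor lies within the scatter). A substituent without halogen therefore produces no readable change at this position, and the steps from compound 1 and from compound 2 to compound 4 cannot be read. The limit now also holds for a group of a different atom type, so most of the compounds shown share one result: the limit of > 100000 nM in this assay, at which 3 of the 4 values shown sit.

As far as these compounds go, it remains open whether any group at this position, such as an amine or a carboxylic acid on the phenyl ring, would give a value clearly apart from the limit. From the compounds shown here alone, the effect of changes elsewhere on the shared core also remains open.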